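The compounds below may be only part of what the source reports. "The series", "measured", "known", "first", "only" and "open" are said of these compounds alone.

Measured in a functional assay on A549 cells (Homo sapiens) for antiproliferative activity, read by MTT assay, with a stated time of 72 h; on this read-out lower numbers stand for stronger inhibition and higher numbers for weaker inhibition:
- compound 1 `O=C(N/N=C/c1ccc(F)cc1)Nc1ccc(Oc2ccnc3[nH]ccc23)c(F)c1`: 680 nM
- compound 2 `O=C(N/N=C/c1ccccc1)Nc1ccc(Oc2ccnc3[nH]ccc23)cc1`: 17200 nM
- compound 3 `CCN(CC)CCn1cccc1/C=N/NC(=O)Nc1ccc(Oc2ccnc3[nH]ccc23)cc1`: 3570 nM

Compound 3 has the second highest of the three numbers, with compound 2 higher and compound 1 lower, both gaps beyond the scatter. Compound 4 `CN1CCN(CCCn2cccc2/C=N/NC(=O)Nc2ccc(Oc3ccnc4[nH]ccc34)cc2)CC1` departs from compound 3 by (4-methylpiperazin-1-yl)methyl in place of diethylamino on a saturated chain carbon, two bonds along the chain from an aromatic nitrogen. Cut one bond further out, this reads 2-(diethylamino)ethyl to 3-(4-methylpiperazin-1-yl)propyl. Going by the values given here, no measured pair isolates this change, so the expectation is anchored on compound 3 at 3570 nM. In this assay no step beyond the scatter is expected, and any direction is tentative. The expected change is a 1.3-fold lower number from compound 3 to compound 4 (0.11 log units; within the scatter). For compound 4 the estimated value is 2800 nM, with an expected range of 800 nM to 9000 nM.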

Compound 4, half-maximal inhibitory concentration: 1640 nM
For compound 4 the middle estimate is 1.7-fold (0.23 log units) above the measured one, and the stated range covers the measured number.
By their numbers in this assay, from the lowest: compound 1; then compound 4; then compound 3; then compound 2.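

On the saturated chain carbon, two bonds along the chain from an aromatic nitrogen, (4-methylpiperazin-1-yl)methyl in place of diethylamino gives a 2.2-fold lower number from compound 3 to compound 4 (0.34 log units; beyond the scatter) in this assay, a modest step. Going by these compounds alone, this is the first one-place comparison, and it shows that this position accepts the larger, ring-bearing group with no loss of activity. No measured data bear on the reason for the step.

The step changes chain length and terminal amine together, leaving their contributions unseparated. A 3-(diethylamino)propyl or 2-(4-methylpiperazin-1-yl)ethyl group would separate them, and a terminal morpholine remains an open comparison.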